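Swapping a halophenyl amide on a shared core

The source may report more compounds than this note shows. Statements on the series, on what has been measured and on what is new or still open speak of the compounds shown alone.

Four compounds share the core seen in compound 1 `O=C(O)C1=Cc2ccccc2OC1(OCc1cc(-c2ccc(F)cc2)no1)C(F)(F)F`. In a functional assay on HeLa cells (Homo sapiens) for inhibition, read by MTT assay, with a stated time of 24 h (on this read-out lower numbers stand for stronger inhibition and higher numbers for weaker inhibition), compound 1 reaches only a limit of the assay, > 150000 nM. Compound 2 `CCOC(=O)C1=Cc2ccccc2OC1(OCc1cn(CC(=O)Nc2ccccc2Br)nn1)C(F)(F)F` likewise gives only a limit in this assay, > 150000 nM. Within the data shown here, compound 3 `CCOC(=O)C1=Cc2ccccc2OC1(OCc1cc(-c2ccc(Br)cc2)no1)C(F)(F)F` is the one member with a number in this assay, 52300 nM. Compound 2 therefore stands at the limit of > 150000 nM in this assay, at which 2 of the 3 values shown sit. Compound 4 `CCOC(=O)C1=Cc2ccccc2OC1(OCc1cn(CC(=O)Nc2cccc(Cl)c2)nn1)C(F)(F)F` differs from compound 2 in one place, namely (3-chlorophenyl in place of 2-bromophenyl on an amide-type nitrogen). Among the measured compounds shown here, no two measured compounds differ in a single place, so no measured step exists to lean on. Compound 4 is expected to remain at the limit, and the step of a number no higher from compound 2 to compound 4 (the limit leaves the size open) is expected to be none beyond the scatter. Compound 4 is estimated at 150000 nM, within a range from 60000 nM to 400000 nM.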

Compound 4, half-maximal inhibitory concentration: 12300 nM
Compound 4: middle estimate off by 12-fold (1.09 log units), on the high side, and the stated range ends above it.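

At this amide-type nitrogen, 3-chlorophenyl in place of 2-bromophenyl gives an at least 12-fold lower number from compound 2 to compound 4 (1.08 log units; beyond the scatter) in this assay, so the group on this nitrogen can move the read-out, which no earlier single-place comparison could show. The full size of the step stays open because compound 2 gives only a limit: the limit of > 150000 nM in this assay, at which 2 of the 4 values shown sit.

The change swaps bromine for chlorine and moves the halogen at once, and the compounds shown do not separate the two. Going by these compounds, how 2-chlorophenyl, 3-bromophenyl or plain phenyl would read on this nitrogen remains open.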